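Bromo to cyano at the weak end of the series

A few compounds are considered here, and "the series" means these few. Any claim that something is new, unique, unknown or untested is made for them only; others in the source may bear on it.

In a functional assay on A549 cells (Homo sapiens) for cytotoxicity, read by MTT assay, with a stated time of 72 h (a lower number here means a stronger inhibitor, a higher number a weaker inhibitor), compound 1 `CNC(=O)c1cc(Oc2ccc(C(=O)/C=C/c3ccc(Cl)c(Cl)c3)cc2)ccn1` gives 33700 nM. Compound 2 `CNC(=O)c1cc(Oc2ccc(C(=O)/C=C/c3ccc(Br)cc3)cc2)ccn1` is reported only as a limit, > 50000 nM, and not as a number. Compound 3 `CNC(=O)c1cc(Oc2ccc(C(=O)/C=C/c3ccc(C#N)cc3)cc2)ccn1` carries cyano in place of bromo on an aromatic carbon, para to a large group: cyano in place of bromo on an aromatic carbon.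

Going by the values given here, one measured step bears on this change, an at least 1.4-fold higher number from compound 1 to compound 2 (0.17 log units; that floor lies within the scatter). Among the compounds with values here, it swaps a different pair of groups on the same aromatic ring, and no measured compound carries cyano, so it gives only a loose guide. No step beyond the scatter is therefore expected in this assay, and no direction is favoured. The expected change is an at least 1.1-fold lower number from compound 2 to compound 3 (0.04 log units; that floor lies within the scatter). Compound 3 is expected at about 45000 nM, with an estimated range of 20000 nM to 90000 nM.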

Compound 3, half-maximal inhibitory concentration: 26400 nM
Compound 3: the middle estimate sits 1.7-fold (0.23 log units) above what was measured, within the range that was stated.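

In this assay compound 2 is reported only as a limit and not as a number: the limit of > 50000 nM in this assay, at which 1 of the 3 values shown sits. Cyano in place of bromo on this aromatic carbon, para to a large group, yields a measured number, but the step can be read only as a floor: an at least 1.8-fold lower number from compound 2 to compound 3 (0.27 log units; that floor lies within the scatter). The other step, a 1.3-fold lower number from compound 1 to compound 3 (0.11 log units; within the scatter), leaves the 4-cyanophenyl and 3,4-dichlorophenyl groups indistinguishable in this assay.

Going by these compounds, the true size of the change from bromo remains open, as the limit does not fix it. Also open, on these data alone, is whether an amine, a carboxylic acid or a longer chain at this position would give a step beyond the scatter in this assay.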